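This account rests on a few compounds, and the source may have more. Where it says the series, first, only, none or still open, it means among the compounds named here.

Measured compounds: compound 1 `CCn1nc(Cc2ccc(OC)c(OC)c2)c2ccccc2c1=O` gives 5300 nM; compound 3 `C=CCn1nc(Cc2ccc(Cl)cc2)c2ccccc2c1=O` gives 2600 nM; compound 2 `CCn1nc(Cc2ccc(OC)cc2)c2ccccc2c1=O` has "not determined" (no result reported).

The study's read-out is a functional assay on aorta with Alpha-1D adrenergic receptor (Rattus norvegicus) as the target; on this read-out higher numbers stand for an effect only at larger amounts of compound and lower numbers for an effect already at smaller amounts. Of the two numbers at hand, compound 1 stands highest with 5300 nM, while compound 3 gives the lower number at 2600 nM, a gap that lies beyond the usual scatter. Compound 2 was not determined, so its place cannot be set.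

The account turns to compound 4 `COc1ccc(Cc2nn(-c3ccccc3)c(=O)c3ccccc23)cc1OC`, which shares its core with compound 1 and differs from it in one place. The change is phenyl in place of ethyl on an aromatic nitrogen. Among the compounds with values here, no measured pair in the set shows the effect of exchanging one group for another at that position, so nothing can be read across directly. The step from compound 1 to compound 4 is therefore expected to be small, and it is estimated as a 1.3-fold lower number from compound 1 to compound 4 (0.12 log units; within the scatter), which may well stay within the scatter in this assay. Compound 4 is accordingly expected to give about 4000 nM, with a plausible range from 1300 nM to 12000 nM.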

Compound 4, half-maximal effective concentration: > 100000 nM
Compound 4: a limit, no number; the forecaster's own chance of this, stated with the estimate: 10%; middle value at least 25-fold (1.39 log units) from the limit.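

In this assay, the nitrogen that carries ethyl in compound 1 proves sensitive to what sits on it: phenyl in place of ethyl gives an at least 18-fold higher number from compound 1 to compound 4 (1.27 log units; beyond the scatter). Within the data shown here, this is the first step in the set between compounds that differ in one place, and it gives the first direct reading of this position, which the earlier compounds could not provide. Compound 4 has a limit of the assay and not a number, which bounds the step on one side only: the limit of > 100000 nM in this assay, at which 1 of the 4 values shown sits.

The compounds shown leave open whether a longer chain such as butyl, or a benzyl group, on that nitrogen would read like compound 1 or like compound 4. They also leave open how a chain ending in an amine would read at this position.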